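Aroyl thiosemicarbazide series: compound 2 to compound 4

The source may hold more compounds than are shown below. What is called first, only, known or untested is meant among the compounds shown, and "the series" means these compounds.

Within the data shown here, compound 2 `O=C(NC(=S)NNc1ncnc2ccccc12)c1cccc(Cl)c1` gives the lowest of the three numbers so far in a functional assay on GLC82 cells (Homo sapiens) for cytotoxicity, read by MTT assay, with a stated time of 72 h (on this read-out lower numbers stand for stronger inhibition and higher numbers for weaker inhibition), at 3240 nM. Compound 3 `COc1cc2ncnc(NNC(=S)NC(=O)c3ccccc3OC)c2cc1OC` comes nearest, with 16000 nM in this assay, and compound 1 `COc1cc2ncnc(NNC(=S)NC(=O)c3ccccc3C)c2cc1OC` is furthest, with 21500 nM in this assay; both gaps lie beyond the scatter. Among the measured compounds shown here, the only step measured between compounds differing in one place is a 1.3-fold lower number from compound 1 to compound 3 (0.13 log units; within the scatter), which does not speak to the change now in question. Compound 4 `Cc1ccccc1C(=O)NC(=S)NNc1ncnc2ccccc12` differs from compound 2 by 2-methylphenyl in place of 3-chlorophenyl on a carbonyl carbon. For the measured compounds named here, no measured pair isolates this exchange. Compound 1 carries the same 2-methylphenyl group as compound 4 but on a different core, so its value and that of compound 2 differ in two places at once and give only a loose hint that the 2-methylphenyl amides sit at higher numbers. Compound 4 is therefore expected to give a higher number, estimated at 7000 nM with a range of 2000 nM to 25000 nM in this assay. The expected step is a 2.2-fold higher number from compound 2 to compound 4 (0.33 log units; beyond the scatter), carrying wide uncertainty.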

Compound 4, half-maximal inhibitory concentration: 13200 nM
Compound 4: middle estimate off by 1.9-fold (0.28 log units), on the low side; the range from low to high includes it.
By their numbers in this assay, from the lowest: compound 2; then compounds 4, 3 and 1 (each within the scatter of the next).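

Holding the core fixed isolates the group on the carbonyl carbon for the first time: in this assay 2-methylphenyl in place of 3-chlorophenyl gives a 4.1-fold higher number from compound 2 to compound 4 (0.61 log units; beyond the scatter) and so separates the two aroyl groups on this core. Among these compounds, the only earlier one-place step, methoxy in place of methyl on an aromatic carbon, gave a 1.3-fold lower number from compound 1 to compound 3 (0.13 log units; within the scatter) and did not separate its two compounds, so this exchange is the first to move the number beyond the scatter. No measurement at hand accounts for the step.

A single pair cannot tell whether the step follows the loss of chlorine, the gain of methyl or the different place of the group on the phenyl ring. Also open, on these data alone, is how the read-out responds to an amine or a carboxylic acid on that ring, or to a longer alkyl chain in place of the ring.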